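The source may hold more compounds than are shown below. What is called first, only, known or untested is meant among the compounds shown, and "the series" means these compounds.

Compound 1 `Cc1ccccc1C(=O)NNC(=O)c1ccc(NS(=O)(=O)c2cnc(O)nc2O)cc1` gives 7040 nM in a functional assay on MDA-MB-231 cells (Homo sapiens) for antiproliferative activity, read by MTT assay, with a stated time of 24 h; on this read-out lower numbers stand for stronger inhibition and higher numbers for weaker inhibition. Compound 2 `Cc1ccc(C(=O)NNC(=O)c2ccc(NS(=O)(=O)c3cnc(O)nc3O)cc2)cc1` carries 4-methylphenyl in place of 2-methylphenyl on a carbonyl carbon. In this assay compound 2 reaches only a limit, > 20000 nM. Accordingly an at least 2.8-fold higher number from compound 1 to compound 2 (0.45 log units; beyond the scatter), a step whose size rests on (the limit of > 20000 nM in this assay, at which 1 of the 3 values shown sits). Compound 3 `Cc1ccccc1C(=O)NNC(=O)c1ccccc1NS(=O)(=O)c1cnc(O)nc1O` has another core; the difference between the cores of compound 1 and compound 3 is not broken down here. In this assay compound 3 gives 5570 nM, within the scatter of the number for compound 1. Compound 4 `Cc1ccc(C(=O)NNC(=O)c2ccccc2NS(=O)(=O)c2cnc(O)nc2O)cc1` is not yet measured; against compound 3 it carries 4-methylphenyl in place of 2-methylphenyl on a carbonyl carbon, the same change as that from compound 1 to compound 2. Compound 4 is therefore expected to give about 18000 nM, because an at least 2.8-fold higher number from compound 1 to compound 2 (0.45 log units; beyond the scatter). For compound 4 the expected range runs from 8000 nM to 40000 nM, with a fair chance that only a limit is reported. The step this estimate means for compound 4 is a 3.2-fold higher number from compound 3 to compound 4 (0.51 log units; beyond the scatter).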

Compound 4, half-maximal inhibitory concentration: > 20000 nM
Compound 4 gave a limit, no number; the forecaster's own chance of this, stated with the estimate: 50%; middle value at least 1.1-fold (0.04 log units) from the limit.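

In this assay compound 4 reaches only a limit, > 20000 nM. Carrying 4-methylphenyl in place of 2-methylphenyl on a carbonyl carbon over to the core of compound 3 gives an at least 3.5-fold higher number from compound 3 to compound 4 (0.55 log units; beyond the scatter). The direction of the change therefore holds on both cores, but this does not show that its size carries over from one core to the other: the same change on two cores in this assay, an at least 2.8-fold higher number (0.45 log units; beyond the scatter) from compound 1 to compound 2 and an at least 3.5-fold higher number (0.55 log units; beyond the scatter) from compound 3 to compound 4; the limit leaves it open whether they differ

The compounds shown leave open how far the number for compound 2 or compound 4 lies past the limit. They also leave open what an unsubstituted phenyl, 2-ethylphenyl or 2-methoxyphenyl on that carbonyl carbon would give on either core.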